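One Methoxy Step in a Thin Growth Inhibition Series

The source may hold more compounds than are shown below. What is called first, only, known or untested is meant among the compounds shown, and "the series" means these compounds.

Among the compounds with values here, in a functional assay on HO8910 cells (Homo sapiens) for inhibition, read by MTT assay, with a stated time of 24 h, tested at 100 ug/mL (on this read-out higher numbers stand for more inhibition of growth at the one concentration tested and lower numbers for less inhibition of growth), compound 1 (`O=C(CCCCC(S)CCS)Nc1ccccc1`) gives 13.7% and holds the only number available so far. Compound 2 (`Cc1cccc(NC(=O)CCCCC(S)CCS)c1`) is recorded as "not active" (no number reported) with no figure attached, so compound 1 has no second number to be ranked against. Compound 3 (`COc1ccc(NC(=O)CCCCC(S)CCS)cc1`) has not yet been measured. It differs from compound 1 by a single change (methoxy in place of hydrogen on an aromatic carbon): methoxy in place of hydrogen on an aromatic carbon, para to a large group. Within the data shown here, no measured pair shows what such a change does, so no step beyond the usual scatter is expected in either direction. The expected step (a number 1.7 percentage points lower from compound 1 to compound 3 (within the scatter)) is an estimate that stays within that scatter. Compound 3 is expected to give 12% in this assay (estimated range 0% to 28%).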

Compound 3, percent growth inhibition at one concentration: 12.6%
Compound 3: the middle estimate sits 0.6 percentage points below what was measured, and the stated range covers the measured number.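

In this assay, within the data shown here, methoxy in place of hydrogen on an aromatic carbon, para to a large group, gives a number 1.1 percentage points lower from compound 1 to compound 3 (within the scatter) and is the first step that can be read at all. Among these compounds, it shows that this change at this place leaves compound 3 indistinguishable from compound 1 at the one concentration tested, so the two now stand as a pair of measured numbers instead of a single one, while the entry for compound 2 carries no number and no step to it can be read. No measurement at hand offers an explanation for this result.

Going by these compounds, whether a hydroxyl group, an amine or a carboxylic acid in the same place would give a step beyond the scatter remains open. So does the effect of a longer chain there in place of the methoxy.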